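The source may hold more compounds than are shown below. What is called first, only, known or untested is meant among the compounds shown, and "the series" means these compounds.

Measured so far:
Compound 1 `C=C1C(=O)[C@]23C[C@@]1(O)CC[C@H]2c1ccc(OS(=O)(=O)c2ccc(C)cc2)c(C)c1[C@@H]3Cn1cc(-c2ccc(Cl)cc2)nn1` in a functional assay on SW480 cells (Homo sapiens) for cytotoxicity, read by MTT assay, with a stated time of 4 days; on this read-out higher numbers stand for weaker inhibition and lower numbers for stronger inhibition: 2390 nM
Compound 2 `C=C1C(=O)[C@]23C[C@@]1(O)CC[C@H]2c1ccc(O)c(C)c1[C@@H]3Cn1cc(-c2ccc(C)cc2)nn1` in this assay : 330 nM

Of these two numbers, compound 2 has the lower one, and it sits well apart from compound 1, beyond the usual scatter, so compound 2 is the stronger inhibitor here. Compound 3 `C=C1C(=O)[C@]23C[C@@]1(O)CC[C@H]2c1ccc(OS(=O)(=O)c2ccc(C)cc2)c(C)c1[C@@H]3Cn1cc(-c2ccc(C)cc2)nn1` has not yet been measured. It differs from compound 2 in one place: (4-methylphenyl)sulfonyl in place of hydrogen on an oxygen on an aromatic ring, so that the hydroxy of compound 2 becomes a ((4-methylphenyl)sulfonyl)oxy group in compound 3. Among the measured compounds shown here, no measured pair in this set isolates exactly this change. For the measured compounds named here, the only other compound that carries the ((4-methylphenyl)sulfonyl)oxy group, compound 1, gives 2390 nM, but it also differs in a second place, so it offers only a loose guide. Compound 3 is therefore expected to show a step toward weaker inhibition, about a 3.6-fold higher number from compound 2 to compound 3 (0.56 log units; beyond the scatter), with the size uncertain. The estimate for compound 3 is 1200 nM, within a range from 400 nM to 3600 nM.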

Compound 3, half-maximal inhibitory concentration: 1460 nM
Compound 3: middle estimate off by 1.2-fold (0.09 log units), on the low side, and the stated range covers the measured number.
By their numbers in this assay, from the lowest: compound 2; then compounds 3 and 1 (each within the scatter of the next).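

In this assay, among the compounds shown here, the change from hydroxy to ((4-methylphenyl)sulfonyl)oxy gives a 4.4-fold higher number from compound 2 to compound 3 (0.65 log units; beyond the scatter), a step beyond the scatter toward weaker inhibition and the first clean reading of this change at this oxygen. Methyl in place of chloro on an aromatic carbon gives a 1.6-fold lower number from compound 1 to compound 3 (0.21 log units; within the scatter), which lies within the scatter, so these two groups cannot be told apart in this assay while the ((4-methylphenyl)sulfonyl)oxy group is present. Nothing measured here explains why the first step occurs.

Going by these compounds, it remains open whether a smaller group on this oxygen, such as a methoxy or an acetoxy group, would weaken inhibition to a similar extent. Also open, on these data alone, is whether chloro and methyl would remain indistinguishable in compounds that keep the free hydroxy.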